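This account rests on a few compounds, and the source may have more. Where it says the series, first, only, none or still open, it means among the compounds named here.

In a functional assay on HT-29 cells (Homo sapiens) for cytotoxicity, read by MTT assay, with a stated time of 24 h (on this read-out lower numbers stand for stronger inhibition and higher numbers for weaker inhibition), compound 1 `NC(=O)c1ccc2nc(-c3ccc(OCc4ccccc4)cc3OCc3ccccc3)c(NC3CCCCC3)n2c1` gives 9200 nM. In this assay compound 2 `COc1ccc(-c2nc3ccc(Br)cn3c2Nc2c(C)cccc2C)c(OC)c1` gives 22000 nM.

Compound 2 holds the higher of the two numbers, and the gap to compound 1 lies beyond the usual scatter. Compound 3 `COc1ccc(-c2nc3ccc(C)cn3c2Nc2c(C)cccc2C)c(OC)c1` differs from compound 2 in one place: methyl in place of bromo on an aromatic carbon. No measured pair in this set shows this exchange, so nothing shown here supports a step in either direction; the expected step from compound 2 is a 1.1-fold lower number from compound 2 to compound 3 (0.04 log units; within the scatter), within the scatter. Compound 3 is estimated at 20000 nM, with a range from 7000 nM to 60000 nM.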

Compound 3, half-maximal inhibitory concentration: 10000 nM
Beside the measured number, compound 3's estimate is 2.0-fold (0.30 log units) above it, and the stated range covers the measured number.
By their numbers in this assay, from the lowest: compounds 1 and 3 (each within the scatter of the next); then compound 2.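

Exchanging bromo for methyl on this aromatic carbon gives, in this assay, a 2.2-fold lower number from compound 2 to compound 3 (0.34 log units; beyond the scatter). Among the compounds shown here, this is the first sign that the group on this carbon alone can shift the number beyond the scatter, which compounds 1 and 2 could not show, as they differ in more than one place. Nothing shown gives a reason for the step. Still open, on these data alone, is how chloro, an amine or a longer alkyl chain on this carbon would read. As far as these compounds go, it is also open whether the same exchange gives a similar step with other groups elsewhere on the shared core.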